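The source may report more compounds than this note shows. Statements on the series, on what has been measured and on what is new or still open speak of the compounds shown alone.

Of the compounds shown here, two have numbers so far. In an in vivo ADME assay on the whole organism (strain BALB/c) for pharmacokinetics, with Mus musculus as the target, read by LC-MS, at a dose of 5 mg/kg by the oral route (a lower number here means slower removal, a higher number faster removal of the compound), compound 1 (`CCCS(=O)(=O)c1ccc(F)c(C#Cc2cc(Cl)ccc2OCC(=O)O)c1`) gives 6.67 mL/min/kg and compound 2 (`CS(=O)(=O)c1ccc(Cl)c(C#Cc2cc(Cl)ccc2OCC(=O)O)c1`) gives 11.7 mL/min/kg. Compound 2 therefore stands level with compound 1, as the two values lie within the usual scatter of each other. Compound 3 (`CS(=O)(=O)c1ccc(F)c(C#Cc2cc(Cl)ccc2OCC(=O)O)c1`) differs from compound 2 by fluoro in place of chloro on an aromatic carbon, ortho to a large group and para to a methylsulfonyl group: fluoro in place of chloro on an aromatic carbon. Within the data shown here, no measured pair shows what this exchange does in this assay, so the expectation is for no step beyond the scatter. The estimate is a small one, a 1.3-fold lower number from compound 2 to compound 3 (0.11 log units; within the scatter), and it is expected to stay within the scatter. For compound 3 the expected clearance is 9 mL/min/kg, with an estimated range of 4 mL/min/kg to 20 mL/min/kg.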

Compound 3, clearance: 6.67 mL/min/kg
For compound 3 the middle estimate is 1.3-fold (0.13 log units) above the measured one; low and high end bracket the measured number.
By their numbers in this assay, from the lowest: compounds 1, 3 and 2 (each within the scatter of the next).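

In this assay, the exchange of chloro for fluoro on this aromatic carbon, para to a methylsulfonyl group, can now be read directly: it gives a 1.8-fold lower number from compound 2 to compound 3 (0.24 log units; within the scatter) and so shows no effect beyond the scatter. Among these compounds, the sulfonyl chain can also be read for the first time, with hydrogen in place of ethyl on a saturated chain carbon bound to a sulfonyl sulfur giving no change at the digits printed from compound 1 to compound 3 (within the scatter) on the fluoro compounds. No measurement offered here explains either step. As far as these compounds go, whether a nitrile or trifluoromethyl on this aromatic carbon, or a longer chain on the sulfonyl group, would move clearance beyond the scatter remains open. So does the effect of an amide in place of the carboxylic acid.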